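Chain-extended amidine analogs in the shared core series

The source may hold more compounds than are shown below. What is called first, only, known or untested is meant among the compounds shown, and "the series" means these compounds.

Measured compounds:
compound 1 `COc1ccc(Br)cc1CCc1c(F)cccc1C(=O)/N=C(\N)NCCN1CCCC1` — 4500 nM
compound 2 `CCCC/N=C(/N)NC(=O)c1cccc(F)c1CCc1cc(Br)ccc1OC` — "not determined" (no result reported)
compound 3 `CCN(CC)CCCC(C)/N=C(/N)NC(=O)c1cccc(F)c1CCc1cc(Br)ccc1OC` — 130 nM

In a functional assay for antagonist activity at Melanocortin receptor 4 (Homo sapiens), read by cAMP accumulation (on this read-out higher numbers stand for weaker inhibition and lower numbers for stronger inhibition), compound 1 gives 4500 nM, the highest of the two numbers available. The nearest measured neighbour, compound 3, gives 130 nM in this assay; the gap between the two lies well beyond the scatter, but the two structures differ in more than one place, so their values are only compared, not read as a single step. In this assay compound 2 gives "not determined" (no result reported), so no number is available for it.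

Compound 4 `COc1ccc(Br)cc1CCc1c(F)cccc1C(=O)/N=C(\N)NCCCN1CCN(C)CC1` follows from compound 1 by the change ((4-methylpiperazin-1-yl)methyl in place of pyrrolidin-1-yl on a saturated chain carbon, two bonds along the chain from an amine nitrogen). Among the compounds with values here, no measured step of this kind exists, so the expectation rests on compound 1 alone and on the comparison with compound 3. The step is expected to run toward stronger inhibition, of moderate size, at the edge of the scatter: a 3.0-fold lower number from compound 1 to compound 4 (0.48 log units; beyond the scatter). On that basis compound 4 is estimated at 1500 nM in this assay, with a range from 400 nM to 6000 nM.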

Compound 4, half-maximal inhibitory concentration: 670 nM
Beside the measured number, compound 4's estimate is 2.2-fold (0.35 log units) above it, within the range that was stated.
By their numbers in this assay, from the lowest: compound 3; then compound 4; then compound 1.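

The first step read at this position shows that the number in this assay responds to the amine end of the chain: (4-methylpiperazin-1-yl)methyl in place of pyrrolidin-1-yl gives a 6.7-fold lower number from compound 1 to compound 4 (0.83 log units; beyond the scatter), a change beyond the scatter. This single step changes both the ring and the chain, since the same difference also reads 2-(pyrrolidin-1-yl)ethyl to 3-(4-methylpiperazin-1-yl)propyl, so the two contributions cannot be told apart. Nothing available explains the step.

Going by these compounds, whether the longer chain or the piperazine ring carries the step remains open. A 3-(pyrrolidin-1-yl)propyl group or a 2-(4-methylpiperazin-1-yl)ethyl group on the same core would separate the two changes, and a morpholine ring would test the role of the second ring nitrogen.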